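The source may report more compounds than this note shows. Statements on the series, on what has been measured and on what is new or still open speak of the compounds shown alone.

Among the compounds with values here, compound 2 `CC(C)(C)ONC(=N)c1ccc2[nH]c(-c3cccc(-c4ccccc4O)c3O)cc2c1` gives 38% in an in vivo ADME assay on the whole organism (strain Sprague-Dawley) for pharmacokinetics, with Rattus norvegicus as the target (on this read-out higher numbers stand for higher oral bioavailability and lower numbers for lower oral bioavailability), the lower of the two numbers measured so far, whereas compound 1 `C=CCO/N=C(/N)c1ccc2[nH]c(-c3cccc(-c4ccccc4O)c3O)cc2c1` gives 100% in this assay. Compound 3 `N/C(=N/C(=O)OCC(Cl)(Cl)Cl)c1ccc2[nH]c(-c3cccc(-c4ccccc4O)c3O)cc2c1` differs from compound 2 by a group of 11 heavy atoms (4 carbon, 2 nitrogen, 2 oxygen, 3 chlorine; no ring) in place of a group of 8 heavy atoms (5 carbon, 2 nitrogen, 1 oxygen; no ring), on an aromatic carbon. Within the data shown here, the only measured step that bears on this, a number 62 percentage points lower from compound 1 to compound 2 (beyond the scatter), also exchanged the group on an aromatic carbon and was large, so a sizeable shift in either direction cannot be excluded; the entering group itself has no measured precedent. The step is expected to be a number 7 percentage points higher from compound 2 to compound 3 (within the scatter). For compound 3 the estimate is 45%, within 15% to 85%.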

Compound 3, oral bioavailability: 14%
Beside the measured number, compound 3's estimate is 31 percentage points above it; measured number below the stated range.
By their numbers in this assay, from the lowest: compound 3; then compound 2; then compound 1.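

Exchanging the group on this aromatic carbon lowers the oral bioavailability read-out in this assay again (a number 24 percentage points lower from compound 2 to compound 3 (beyond the scatter)), and the change on the double-bonded nitrogen, (2,2,2-trichloroethoxy)carbonyl in place of allyloxy, gives the largest step of the series (a number 86 percentage points lower from compound 1 to compound 3 (beyond the scatter)). All three groups at this position are thus separated beyond the scatter, with the trichloroethoxycarbonyl group of compound 3 lowest. Nothing measured here accounts for these drops. On these data alone, whether the chlorines or the carbonyl matter stays open, as does how an ethoxycarbonyl or methoxy group on that nitrogen would read.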